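Selenium to sulfur on a bis-acyl isoselenourea core

This account rests on a few compounds, and the source may have more. Where it says the series, first, only, none or still open, it means among the compounds named here.

Three compounds have been examined so far in a functional assay on MCF7 cells (Homo sapiens) for cytotoxicity, read by MTT assay, with a stated time of 72 h; a higher number here means a weaker inhibitor of growth, a lower number a stronger inhibitor of growth. Compound 1 `CS/C(=N\C(=O)c1cc(-c2ccccc2)nc2ccccc12)NC(=O)c1cc(-c2ccccc2)nc2ccccc12` gives 87700 nM. Compound 2 `O=C(/N=C(/NC(=O)c1ccco1)[Se]Cc1ccccc1)c1ccco1` gives 58000 nM. Compound 3 `C[Se]/C(=N\C(=O)c1cnc2ccccc2c1)NC(=O)c1cnc2ccccc2c1` gives 8030 nM, the lowest of the three numbers: compound 2 stands nearest to it, and compound 1 furthest, both of them beyond the scatter of this assay.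

Compound 4 `CS/C(=N\C(=O)c1cnc2ccccc2c1)NC(=O)c1cnc2ccccc2c1` has not yet been measured. It differs from compound 3 in one place: a group of 2 heavy atoms (1 carbon, 1 sulfur; no ring) in place of a group of 2 heavy atoms (1 carbon, 1 selenium; no ring), on a carbon with a double bond to nitrogen. Going by the values given here, no pair of measured compounds differs in exactly this way, so the size of the step has to be guessed. Among the compounds with values here, compound 1, the only other compound carrying a methylsulfanyl group on that carbon, gives 87700 nM in this assay, but it also carries a different acyl group on each amide-type nitrogen, so its number says little about the selenium-to-sulfur swap on its own.

The author expects the number for compound 4 to rise moderately beyond the scatter, with the step from compound 3 to compound 4 estimated at a 3.1-fold higher number from compound 3 to compound 4 (0.49 log units; beyond the scatter). For compound 4 the estimate in this assay is 25000 nM, with a range from 8000 nM to 80000 nM.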

Compound 4, concentration for total growth inhibition: > 100000 nM
Compound 4: no number, only a limit (the forecaster's own chance of this, stated with the estimate: 10%); middle value at least 4.0-fold (0.60 log units) from the limit.
By their numbers in this assay, from the lowest: compound 3; then compounds 2 and 1 (each within the scatter of the next). At a limit, above all of these: compound 4.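

In this assay, going by these compounds alone, the exchange of selenium for sulfur on a carbon with a double bond to nitrogen gives an at least 12-fold higher number from compound 3 to compound 4 (1.09 log units; beyond the scatter) with both acyl groups unchanged, and this is the first comparison here in which a single change can be read on its own. Compound 4 stands at > 100000 nM as a limit of the assay, not a number. Among this pair, growth inhibition in these cells therefore depends strongly on the atom at this place, with the selenium compound the stronger, while the true size of the step remains bounded from one side only: the limit of > 100000 nM in this assay, at which 1 of the 4 values shown sits.

Compound 1 and compound 2 differ from compound 3 in more than one place, so the compounds shown leave open whether selenium holds the same advantage when the acyl groups are different. They also leave open how the number would move with an ethyl chain on the selenium, or with an amine or a methoxy group on that same carbon in place of the whole selenium-bearing group.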